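Aryl variation on the piperazine nitrogen: step to compound 3

The compounds below may be only part of what the source reports. "The series", "measured", "known", "first", "only" and "open" are said of these compounds alone.

Compound 1 `Nc1scc(CN2CCN(c3cccnc3)CC2)c1C(=O)c1ccc(Cl)cc1` and compound 2 `Nc1scc(CN2CCN(c3ccccc3F)CC2)c1C(=O)c1ccc(Cl)cc1` share one core and differ only in the aryl group on the ring amine nitrogen. In a functional assay on CHO cells with adenosine receptor A1 (Homo sapiens) as the target, read by cAMP accumulation and immunoassay, with a stated time of 6 min, tested at 1 uM (on this read-out higher numbers stand for a weaker effect at the one concentration tested and lower numbers for a stronger effect), compound 1 gives -2.7% and compound 2 gives -9.2%; the step of a number 6.5 percentage points lower from compound 1 to compound 2 (within the scatter) is within the scatter, so the two numbers are read as the same. Compound 2 thus sits at the low end of the two numbers shown, but not separated from compound 1.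

Compound 3 `Nc1scc(CN2CCN(c3ccc(F)c(Cl)c3)CC2)c1C(=O)c1ccc(Cl)cc1` carries the change (3-chloro-4-fluorophenyl in place of 2-fluorophenyl on an amine nitrogen in a ring). For the measured compounds named here, the one measured step that bears on it, a number 6.5 percentage points lower from compound 1 to compound 2 (within the scatter), exchanged the aryl group at the same nitrogen and produced nothing beyond the scatter. Compound 3 is therefore expected to show no step beyond the scatter, a number 3.2 percentage points higher from compound 2 to compound 3 (within the scatter). For compound 3 the estimate is -6%, with a range from -18% to 6%.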

Compound 3, a percentage reported as activity, at one concentration (the size of the read-out at that concentration, not a potency): -60%
Estimate against measurement, compound 3: 54 percentage points above, outside the stated range (below it).
By their numbers in this assay, from the lowest: compound 3; then compounds 2 and 1 (each within the scatter of the next).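

In this assay the aryl group on the amine nitrogen in a ring proves to be a position that can move the read-out: 3-chloro-4-fluorophenyl in place of 2-fluorophenyl gives a number 50.8 percentage points lower from compound 2 to compound 3 (beyond the scatter) and in place of pyridin-3-yl gives a number 57.3 percentage points lower from compound 1 to compound 3 (beyond the scatter), whereas the exchange between the two earlier aryl groups stayed within the scatter. The change adds a chlorine and also alters where the fluorine stands, so the step cannot be assigned to either alteration alone. Nothing at hand explains the size of this step.

Open, going by these compounds, is whether 3-chlorophenyl or 4-fluorophenyl alone would reproduce the step. Also open, on these data alone, is how 3,4-dichlorophenyl or 3-methoxyphenyl would read at this nitrogen, and whether the stronger effect seen at the one concentration tested would also appear at other concentrations.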